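Fluoro for Methoxy on the Pyridyl Arm of Compound 1

A few compounds are considered here, and "the series" means these few. Any claim that something is new, unique, unknown or untested is made for them only; others in the source may bear on it.

Compound 1, `COc1cc(-c2nc(C(c3ccc(F)cc3)c3ccc(F)cc3)sc2CC(=O)O)ccn1`, gives 60% in an in vitro functional assay on HEK285-7 cells for antagonist activity at prostaglandin D2 receptor 2 (Homo sapiens), read by BRET and beta-arrestin recruitment; on this read-out lower numbers stand for smaller maximal responses and higher numbers for larger maximal responses.
Compound 2, `CCC(c1ccccc1)c1nc(-c2ccc(Cl)cc2)c(CC(=O)O)s1`, gives 50%.
Compound 3, `COc1ccc(C(c2ccccc2)c2nc(-c3ccc(Cl)cc3)c(CC(=O)O)s2)cc1`, gives 80%.

Among the three measured compounds, compound 1 holds the second highest number. Its nearest neighbour is compound 2, whose value lies within the scatter of repeated measurements, so no order between them can be read; compound 3 stands beyond the scatter above compound 1.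

Compound 4, `O=C(O)Cc1sc(C(c2ccc(F)cc2)c2ccc(F)cc2)nc1-c1ccnc(F)c1`, has not yet been measured. It differs from compound 1 in a single place: fluoro in place of methoxy on an aromatic carbon. For the measured compounds named here, the one measured step, a number 30 percentage points higher from compound 2 to compound 3 (beyond the scatter), concerns a different position, the saturated chain carbon bound to two aromatic carbons, and leaves the six-membered aromatic ring with 1 nitrogen untouched; it therefore does not bear directly on the change from compound 1 to compound 4. Going by the values given here, no measured pair shows an exchange of methoxy for fluoro.

With nothing in the data pointing one way or the other, the step in this assay from compound 1 to compound 4 is expected to stay within the scatter, no change at the digits printed from compound 1 to compound 4 (within the scatter). Compound 4 is accordingly estimated at 60%, with a range from 40% to 80%.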

Compound 4, largest response reached (reported as efficacy), in percent of the reference or control that the assay uses: 80%
For compound 4 the middle estimate is 20 percentage points below the measured one; the range from low to high includes it.
By their numbers in this assay, from the lowest: compounds 2 and 1 (each within the scatter of the next); then compounds 3 and 4 (each within the scatter of the next).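

In this assay there is a number 20 percentage points higher from compound 1 to compound 4 (beyond the scatter) when the 2-methoxypyridin-4-yl arm becomes 2-fluoropyridin-4-yl. For the compounds shown here, this is the first measured sign that the read-out responds to what sits on this aromatic carbon next to the ring nitrogen, a part of the molecule that the earlier step on the saturated chain carbon left untouched. Nothing measured here accounts for the change from methoxy, with its two heavy atoms and one hydrogen-bond acceptor, to fluoro, with one heavy atom and no hydrogen-bond acceptor.

Going by these compounds, this single pair cannot separate the loss of methoxy from the arrival of fluoro, so it remains open whether chloro, an amine or a plain hydrogen on the same carbon would read like compound 1 or like compound 4. Also open, on these data alone, is whether an exchange of methoxy for fluoro would give a comparable step on a core other than that of compound 1.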